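Exocyclic thiazolidinedione in place of the imidazolidinedione arm

The compounds below may be only part of what the source reports. "The series", "measured", "known", "first", "only" and "open" are said of these compounds alone.

Compound 2 `CC(C)C(CC1C(=O)NC(=O)N1C)c1ccc(-c2ccc3cccc(F)c3c2)[nH]c1=O` gives 65 nM in a functional assay on CHO cells for antagonist activity at prostaglandin E2 receptor EP3 subtype (Homo sapiens), read by cAMP accumulation, with a stated time of 30 min; a lower number here means a stronger inhibitor, a higher number a weaker inhibitor. Compound 1 `CCc1cccc2ccc(-c3ccc(C(/C=C4\OC(=O)NC4=O)(CC)CC)c(=O)[nH]3)cc12` gives 91 nM in this assay, and the two values lie within the scatter of each other. Compound 3 `CC(C)[C@H](C[C@H]1OC(=O)NC1=O)c1ccc(-c2ccc3cccc(F)c3c2)[nH]c1=O` gives 15 nM in this assay, a lower number beyond the scatter, so compound 2 holds the second highest of the three numbers. Compound 4 `CC(C)C(/C=C1\SC(=O)NC1=O)c1ccc(-c2ccc3cccc(F)c3c2)[nH]c1=O` carries a group of 8 heavy atoms (4 carbon, 1 nitrogen, 2 oxygen, 1 sulfur; one five-membered non-aromatic ring with 2 hetero atoms) in place of a group of 9 heavy atoms (5 carbon, 2 nitrogen, 2 oxygen; one five-membered non-aromatic ring with 2 hetero atoms), on a saturated chain carbon bound to an aromatic carbon and a saturated chain carbon. For the measured compounds named here, no measured pair isolates this change; the nearest hint is compound 1, which also bears a ring joined through a double bond on a differently substituted core and gives a number close to compound 2. A small step is expected, downward if anything, possibly within the scatter. Compound 4 is estimated at 50 nM, with a range of 15 nM to 160 nM. The expected step is a 1.3-fold lower number from compound 2 to compound 4 (0.11 log units; within the scatter).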

Compound 4, half-maximal inhibitory concentration: 27 nM
Beside the measured number, compound 4's estimate is 1.9-fold (0.27 log units) above it; the range from low to high includes it.
By their numbers in this assay, from the lowest: compounds 3 and 4 (each within the scatter of the next); then compounds 2 and 1 (each within the scatter of the next).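

On the saturated chain carbon bound to an aromatic carbon and a saturated chain carbon, the (3-methyl-2,5-dioxoimidazolidin-4-yl)methyl arm is not required for activity in this assay: a sulfur-bearing ring joined through a double bond gives a 2.4-fold lower number from compound 2 to compound 4 (0.38 log units; beyond the scatter). For the compounds shown here, this is the first change in one place that can be read, and it is a modest step. No measurement bearing on the origin of this step is available.

On these data alone, whether the sulfur or the double bond carries the step remains open. Also open, as far as these compounds go, is how a carboxylic acid or a tetrazole would fare at this position.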